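A few compounds are considered here, and "the series" means these few. Any claim that something is new, unique, unknown or untested is made for them only; others in the source may bear on it.

This account follows a pair of substituted lactones and a third member that has not yet been tested. Compound 1 `O=C1OC[C@H](Cc2ccccc2)[C@H]1Cc1ccc(OC(F)(F)F)cc1` and compound 2 `Cc1ccccc1C[C@H]1COC(=O)[C@@H]1Cc1ccc(Cl)c(Cl)c1` share a core and differ in the groups on both chain carbons. In a functional assay on HL-60 cells (Homo sapiens) for cytotoxicity, read by WST assay, with a stated time of 48 h (on this read-out higher numbers stand for an effect only at larger amounts of compound and lower numbers for an effect already at smaller amounts), compound 1 gives 27000 nM, and in this assay compound 2 gives 22000 nM. The two numbers lie within the usual scatter of each other, so neither compound can be called more or less active than the other on these data; compound 2 simply stands at the lower of the two numbers.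

Compound 3 `CCc1ccc(C[C@H]2COC(=O)[C@@H]2Cc2ccc(Cl)c(Cl)c2)cc1` is the untested member. It differs from compound 2 in one place: 4-ethylphenyl in place of 2-methylphenyl on a saturated chain carbon bound to a saturated ring carbon. Among the measured compounds shown here, no measured pair in this set shows what such a change does, so there is no step to lean on. The expectation is that the step of a 1.1-fold lower number from compound 2 to compound 3 (0.04 log units; within the scatter) is small, with no direction beyond the scatter. Compound 3 is therefore expected to give about 20000 nM, with a range from 8000 nM to 50000 nM.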

Compound 3, half-maximal effective concentration: 16000 nM
Compound 3: the middle estimate sits 1.3-fold (0.10 log units) above what was measured; low and high end bracket the measured number.
By their numbers in this assay, from the lowest: compounds 3, 2 and 1 (each within the scatter of the next).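

Among the compounds shown here, for the first time the set holds a comparison in which only one place differs: in this assay, 4-ethylphenyl in place of 2-methylphenyl on a saturated chain carbon bound to a saturated ring carbon gives a step that stays inside the usual variation (a 1.4-fold lower number from compound 2 to compound 3 (0.14 log units; within the scatter)). With the rest of the structure held fixed, this position therefore accepts either of these two carbon-only aromatic groups without a difference that can be told from the scatter, although this single pair says nothing about other groups there. Nothing measured alongside these numbers offers an explanation for this result.

The compounds shown leave open whether anything other than an alkyl-substituted phenyl at this place would shift the number beyond the scatter, for instance an amine or a carboxylic acid on that ring, or a longer chain in place of the ethyl group. They also leave open whether the same exchange would read alike with the group that compound 1 carries on its other chain carbon.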